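The source may hold more compounds than are shown below. What is called first, only, known or untested is meant among the compounds shown, and "the series" means these compounds.

Measured compounds in this set:
- compound 1 `COc1ccc(CN(C(C)=O)c2cc(OC)c(OC)c(OC)c2)cc1O` gives 79 nM
- compound 2 `C#CC(=O)N(Cc1ccc(OC)c(O)c1)c1cc(OC)c(OC)c(OC)c1` gives 170 nM
- compound 3 `COc1ccc(CNc2cc(OC)c(OC)c(OC)c2)cc1F` gives 39700 nM

In a functional assay on MGC-803 cells (Homo sapiens) for inhibition, read by MTT assay, with a stated time of 48 h (on this read-out lower numbers stand for stronger inhibition and higher numbers for weaker inhibition), compound 2 stands second highest of the three numbers, nearest to compound 1 and far from compound 3, whose number is much higher. Compound 4 `CCC(=O)N(Cc1ccc(OC)c(O)c1)c1cc(OC)c(OC)c(OC)c1` differs from compound 2 in one place: ethyl in place of ethynyl on a carbonyl carbon. Among the measured compounds shown here, the only measured step at this carbonyl carbon is a 2.2-fold higher number from compound 1 to compound 2 (0.33 log units; beyond the scatter), a modest rise. As compound 4 carries no triple bond, as compound 1 does not, the number for compound 4 is expected to fall back toward that of compound 1, giving an expected step of a 1.7-fold lower number from compound 2 to compound 4 (0.23 log units; within the scatter). The estimate for compound 4 is 100 nM, within 40 nM to 300 nM.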

Compound 4, half-maximal inhibitory concentration: 50 nM
Beside the measured number, compound 4's estimate is 2.0-fold (0.30 log units) above it; low and high end bracket the measured number.
By their numbers in this assay, from the lowest: compounds 4 and 1 (each within the scatter of the next); then compound 2; then compound 3.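

In this assay, ethyl in place of ethynyl on the carbonyl carbon gives a 3.4-fold lower number from compound 2 to compound 4 (0.53 log units; beyond the scatter), so the higher number seen with ethynyl does not carry over to a saturated group of the same heavy-atom count. Methyl in place of hydrogen on the saturated chain carbon bound to the carbonyl carbon gives a 1.6-fold lower number from compound 1 to compound 4 (0.20 log units; within the scatter), so the position accepts ethyl as well as methyl without a readable change. No available evidence bears on the gap between ethyl and ethynyl.

From the compounds shown here alone, whether a longer chain such as butyl, a branched isopropyl or a chain carrying an amine holds the number at this level remains open. Also open, going by these compounds, is how a vinyl group, with a double bond, would compare with ethyl and ethynyl.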